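The source may hold more compounds than are shown below. What is called first, only, known or untested is meant among the compounds shown, and "the series" means these compounds.

Working notes on the series. Compound 1 `CCOC(=O)C1=Cc2ccccc2OC1(OCc1cn(-c2ccc(F)c([N+](=O)[O-])c2)nn1)C(F)(F)F` gives 15600 nM in a functional assay on HeLa cells (Homo sapiens) for inhibition, read by MTT assay, with a stated time of 24 h; on this read-out higher numbers stand for weaker inhibition and lower numbers for stronger inhibition. Compound 2 `CCOC(=O)C1=Cc2ccccc2OC1(OCc1cn(-c2ccc(F)c(Cl)c2)nn1)C(F)(F)F` gives 22700 nM in this assay; the step of a 1.5-fold higher number from compound 1 to compound 2 (0.16 log units; within the scatter) lies within the scatter, so compound 2 stands with compound 1 and the two numbers are not separated. Compound 3 `CCOC(=O)C1=Cc2ccccc2OC1(OCc1cn(CC(=O)Nc2ccc(I)cc2Cl)nn1)C(F)(F)F` carries ((2-chloro-4-iodophenyl)carbamoyl)methyl in place of 3-chloro-4-fluorophenyl on an aromatic nitrogen. Among the compounds with values here, the single measured step concerns a different change at a different place and stayed within the scatter, so nothing supports a shift in either direction. Compound 3 is therefore expected to sit near the measured numbers, with a 1.0-fold lower number from compound 2 to compound 3 (0.01 log units; within the scatter). The estimate for compound 3 in this assay is 22000 nM, between 7000 nM and 70000 nM.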

Compound 3, half-maximal inhibitory concentration: 26100 nM
Estimate against measurement, compound 3: 1.2-fold (0.07 log units) below, within the range that was stated.
By their numbers in this assay, from the lowest: compounds 1, 2 and 3 (each within the scatter of the next).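

At the aromatic nitrogen of the five-membered ring, the change to ((2-chloro-4-iodophenyl)carbamoyl)methyl adds a hydrogen-bond donor and a carbonyl, yet a 1.1-fold higher number from compound 2 to compound 3 (0.06 log units; within the scatter) and a 1.7-fold higher number from compound 1 to compound 3 (0.22 log units; within the scatter) both lie within the scatter in this assay. This position therefore accepts a larger substituent with an amide without any separation of the numbers, which the change on the aromatic carbon could not show. No measurement on hand accounts for this result. Open, as far as these compounds go, is whether an amine or a carboxylic acid on this nitrogen would move the number beyond the scatter.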